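Spiro pyrazolone dienones: bromo and methyl placement

The source may report more compounds than this note shows. Statements on the series, on what has been measured and on what is new or still open speak of the compounds shown alone.

Working notes on four compounds sharing one core. Compound 1 `CC1=NN(c2ccccc2)C(=O)C12C=CC(=O)C=C2c1cccc(C)c1` and compound 2 `CC1=NN(c2ccccc2)C(=O)C12C=CC(=O)C=C2c1ccc(C)cc1` differ only as 3-methylphenyl in place of 4-methylphenyl on a double-bonded ring carbon. In a functional assay on MDA-MB-231 cells (Homo sapiens) for antiproliferative activity, read by CCK-8 assay, with a stated time of 72 h (on this read-out lower numbers stand for stronger inhibition and higher numbers for weaker inhibition), compound 1 gives 85800 nM and compound 2 gives 91900 nM; the step is a 1.1-fold lower number from compound 2 to compound 1 (0.03 log units; within the scatter). Compound 3 `CC1=NN(c2ccc(Br)cc2)C(=O)C12C=CC(=O)C=C2c1ccc(C)cc1` differs from compound 2 as bromo in place of hydrogen on an aromatic carbon; in this assay compound 3 gives 15900 nM, a step of a 5.8-fold lower number from compound 2 to compound 3 (0.76 log units; beyond the scatter), and compound 3 stands lowest of the three. Compound 4 `CC1=NN(c2ccc(Br)cc2)C(=O)C12C=CC(=O)C=C2c1cccc(C)c1` is not yet measured. It differs from compound 3 as 3-methylphenyl in place of 4-methylphenyl on a double-bonded ring carbon, the same change at the same place as from compound 2 to compound 1. The expected step is a 1.1-fold lower number from compound 3 to compound 4 (0.03 log units; within the scatter), which rests on the earlier step of a 1.1-fold lower number from compound 2 to compound 1 (0.03 log units; within the scatter) lying within the scatter. Compound 4 is therefore expected to give about 15000 nM in this assay, between 7000 nM and 32000 nM.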

Compound 4, half-maximal inhibitory concentration: 2890 nM
For compound 4 the middle estimate is 5.2-fold (0.72 log units) above the measured one; the measured number lies below the stated range.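

With bromo present, 3-methylphenyl in place of 4-methylphenyl gives a 5.5-fold lower number from compound 3 to compound 4 (0.74 log units; beyond the scatter) in this assay, so this change does not carry over unchanged from the core of compound 2: the same change on two cores in this assay, a 1.1-fold lower number (0.03 log units; within the scatter) from compound 2 to compound 1 and a 5.5-fold lower number (0.74 log units; beyond the scatter) from compound 3 to compound 4, 5.1-fold (0.71 log units) apart, beyond the scatter of two such steps

Read the other way, bromo in place of hydrogen gives a 30-fold lower number from compound 1 to compound 4 (1.47 log units; beyond the scatter), and its size depends on which methylphenyl group is present: the same change on two cores in this assay, a 5.8-fold lower number (0.76 log units; beyond the scatter) from compound 2 to compound 3 and a 30-fold lower number (1.47 log units; beyond the scatter) from compound 1 to compound 4, 5.1-fold (0.71 log units) apart, beyond the scatter of two such steps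

Both comparisons rest on the same four compounds, so they show one interaction between the two changes; they do not show its cause or whether it extends beyond these compounds.

Open, going by these compounds, is whether the same dependence appears with chloro or methoxy in place of the bromo. Also open, on these data alone, is what an amine or a carboxylic acid on the methylphenyl ring would do.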